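A chlorine swap on a compound without a reading

The source may report more compounds than this note shows. Statements on the series, on what has been measured and on what is new or still open speak of the compounds shown alone.

- compound 1 `CC(Sc1nnc(-c2ccncc2)s1)C(=O)NCc1ccccc1Cl`: > 50000 nM
- compound 2 `O=C(CSc1nnc(-c2ccncc2)s1)NCc1ccccc1Cl`: "not determined" (no result reported)
- compound 3 `CC(CSc1nnc(-c2ccncc2)s1)C(=O)Nc1c(Cl)cccc1Cl`: > 50000 nM
- compound 4 `O=C(CSc1nnc(-c2ccncc2)s1)NCc1ccc(Cl)cc1`: not yet measured

These compounds belong to a small series tested in an ADME assay on HepG2 cells (Homo sapiens) for cytotoxicity, with a stated time of 3 days; on this read-out lower numbers stand for higher toxicity in this test and higher numbers for lower toxicity in this test. Compound 2 has no number to place it, as its entry reads "not determined" (no result reported). Its standing can only be inferred from the two other compounds measured. Compound 1 gives > 50000 nM, which is a limit of the assay and not a number. Compound 3 gives > 50000 nM, which is also a limit. Together they form the only evidence available: the limit of > 50000 nM in this assay, at which 2 of the 3 values shown sit.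

The step followed here is 4-chlorophenyl in place of 2-chlorophenyl on a saturated chain carbon bound to an amide-type nitrogen. Put simply, 4-chlorophenyl stands in place of 2-chlorophenyl on a saturated chain carbon bound to an amide-type nitrogen. For the measured compounds named here, no measured pair of compounds shows this change on its own, and compound 2 offers no starting value. The expectation therefore rests on compound 1, with its limit of > 50000 nM, and on compound 3, with its limit of > 50000 nM. No step beyond the usual scatter is expected in this assay, and a report of the same limit is likely. The estimate for compound 4 is 60000 nM, with an expected range from 30000 nM to 100000 nM.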

Compound 4, half-maximal cytotoxic concentration: > 50000 nM
Compound 4: a limit, no number; the forecaster's own chance of this, stated with the estimate: 85%; the middle value does not contradict the limit.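

In this assay compound 4 gives > 50000 nM, which is a limit of the assay and not a number. For the compounds shown here, the entry for compound 2 reads "not determined" (no result reported), and no step to compound 4 can be read. The compounds shown leave open whether 2-chlorobenzyl and 4-chlorobenzyl differ at all in this assay.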